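Swapping an aryl group for a benzyl group on the core

A few compounds are considered here, and "the series" means these few. Any claim that something is new, unique, unknown or untested is made for them only; others in the source may bear on it.

Measured so far:
- compound 1 `C=C(Br)C(=O)Nc1cccc(-c2cn3nc(-c4ccc(C)cc4)sc3n2)c1`: 1200 nM
- compound 2 `C=C(Br)C(=O)Nc1cccc(-c2cn3c(-c4ccccc4)csc3n2)c1`: 1300 nM

In a functional assay on FM3A cells (Mus musculus) for inhibition, read by cell counting, with a stated time of 2 days (on this read-out lower numbers stand for stronger inhibition and higher numbers for weaker inhibition), compound 1 gives 1200 nM, and compound 2 gives 1300 nM, a number within the usual scatter of compound 1, so the two cannot be told apart. Compound 3 `C=C(Br)C(=O)Nc1cccc(-c2cn3nc(Cc4ccc(Cl)cc4)sc3n2)c1` has not yet been measured. It differs from compound 1 in one place: 4-chlorobenzyl in place of 4-methylphenyl on an aromatic carbon. For the measured compounds named here, no measured pair tells how this assay responds to such a change, so only a small step, if any, beyond the scatter is expected for a 1.3-fold higher number from compound 1 to compound 3 (0.10 log units; within the scatter). Compound 3 is therefore estimated at 1500 nM, within a range from 500 nM to 4500 nM.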

Compound 3, half-maximal inhibitory concentration: 1100 nM
Beside the measured number, compound 3's estimate is 1.4-fold (0.13 log units) above it; low and high end bracket the measured number.
By their numbers in this assay, from the lowest: compounds 3, 1 and 2 (each within the scatter of the next).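

In this assay, exchanging 4-methylphenyl for 4-chlorobenzyl gives a 1.1-fold lower number from compound 1 to compound 3 (0.04 log units; within the scatter), so the two compounds cannot be told apart. This aromatic carbon of the shared core therefore takes a ring attached through an added carbon, and carrying chlorine, with no step beyond the scatter. Nothing available explains this result. From the compounds shown here alone, the added carbon and the chlorine arrive together, so what each does alone stays open. Also open, going by these compounds, is how the number would respond to an amine, a carboxylic acid or a longer chain on this carbon.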